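Phenyl in Place of Pentyl: an Expected Loss of Potency

The compounds below may be only part of what the source reports. "The series", "measured", "known", "first", "only" and "open" are said of these compounds alone.

Of the compounds shown here, three sharing one core have been measured in a functional assay on K562 cells (Homo sapiens) for inhibition, read by fluorescence, with a stated time of 72 h; a lower number here means a stronger inhibitor of growth, a higher number a weaker inhibitor of growth. Compound 1 `CCCCCc1cc2nn(-c3ccccc3)cc2c(C)n1` gives 6900 nM. Compound 2 `CCCCc1cc2nn(-c3ccccc3)cc2cn1` gives 6700 nM, a number indistinguishable from that of compound 1 within the scatter. Compound 3 `CC(C)c1nc(-c2ccccc2)cc2nn(-c3ccccc3)cc12` gives 36800 nM, a clearly higher number than compound 1, beyond the scatter, so compound 1 sits second highest among the three, close to compound 2 and well apart from compound 3.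

The step under consideration leads from compound 1 to compound 4 `Cc1nc(-c2ccccc2)cc2nn(-c3ccccc3)cc12`, which has not yet been measured in this assay. The change is phenyl in place of pentyl on an aromatic carbon. Compound 3 also carries a phenyl at this position and differs from compound 4 only in the group of one heavy atom versus a larger alkyl group, and its weaker number suggests that the phenyl at this position is associated with a higher value in this series.

Compound 4 is therefore expected to give a higher number than compound 1, with an estimated step of a 2.9-fold higher number from compound 1 to compound 4 (0.46 log units; beyond the scatter), beyond the scatter but short of the gap to compound 3. The estimate for compound 4 is 20000 nM, ranging from 7000 nM to 60000 nM.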

Compound 4, concentration for 50% growth inhibition: 6300 nM
Estimate against measurement, compound 4: 3.2-fold (0.50 log units) above, and the stated range ends above it.
By their numbers in this assay, from the lowest: compounds 4, 2 and 1 (each within the scatter of the next); then compound 3.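

In this assay, the exchange on this aromatic carbon shows no effect that can be told from the scatter: phenyl in place of pentyl gives a 1.1-fold lower number from compound 1 to compound 4 (0.04 log units; within the scatter). With the methyl group present in both compounds, a six-membered aromatic ring of carbon and an open pentyl chain are therefore not distinguished at this position. The high number of compound 3 cannot be read as a penalty for phenyl, since with phenyl kept, methyl in place of isopropyl gives a 5.8-fold lower number from compound 3 to compound 4 (0.77 log units; beyond the scatter), a step that rests on this single pair. Nothing shown here bears on why either step has the size it has.

The compounds shown leave open whether this aromatic carbon stays as indifferent to an amine, a carboxylic acid or a chain longer than pentyl as it does to phenyl and pentyl, or to a phenyl carrying a fluorine or a methoxy group. They also leave open whether isopropyl in place of methyl would give a similar step with pentyl on the aromatic carbon rather than phenyl.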